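Capping a hydroxy group with ethoxycarbonyl

A few compounds are considered here, and "the series" means these few. Any claim that something is new, unique, unknown or untested is made for them only; others in the source may bear on it.

Measured in a functional assay on SiHa cells (Homo sapiens) for antiproliferative activity, read by CCK-8 assay, with a stated time of 72 h; on this read-out lower numbers stand for stronger inhibition and higher numbers for weaker inhibition:
- compound 1 `COc1ccc(-c2cncnc2-c2cc(OC)c(OC)c(OC)c2)cc1`: 2850 nM
- compound 2 `COc1ccc(-c2cncnc2-c2cc(OC)c(OC)c(OC)c2)cc1O`: 2750 nM

Among the compounds with values here, only two numbers exist so far, and they cannot be told apart. Compound 2, at 2750 nM, stands level with compound 1, at 2850 nM. Within the data shown here, the one measured step is a 1.0-fold lower number from compound 1 to compound 2 (0.02 log units; within the scatter), and it came from placing hydroxy in place of hydrogen on an aromatic carbon.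

Compound 3 `CCOC(=O)Oc1cc(-c2cncnc2-c2cc(OC)c(OC)c(OC)c2)ccc1OC` changes that same hydroxy: ethoxycarbonyl in place of hydrogen on an oxygen on an aromatic ring. Put simply, hydroxy becomes (ethoxycarbonyl)oxy, with ethoxycarbonyl in place of hydrogen on an oxygen on an aromatic ring.

Among the measured compounds shown here, no measured compound carries this group, so the evidence is indirect. For the measured compounds named here, the only guide is a 1.0-fold lower number from compound 1 to compound 2 (0.02 log units; within the scatter), a change at a different kind of atom that left the number within the scatter. On that thin basis, no shift beyond the scatter is expected in either direction in this assay, though the range must stay wide.

The expected change is a 1.1-fold higher number from compound 2 to compound 3 (0.04 log units; within the scatter).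

For compound 3 the estimated value is 3000 nM, with an expected range from 1300 nM to 7000 nM.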

Compound 3, half-maximal inhibitory concentration: 1890 nM
For compound 3 the middle estimate is 1.6-fold (0.20 log units) above the measured one; low and high end bracket the measured number.
By their numbers in this assay, from the lowest: compounds 3, 2 and 1 (each within the scatter of the next).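

Compound 3 shows that this oxygen on an aromatic ring can carry ethoxycarbonyl, with its 5 heavy atoms, in place of a single hydrogen without a shift that stands out from the scatter in this assay: the step is a 1.5-fold lower number from compound 2 to compound 3 (0.16 log units; within the scatter). The hydrogen of the hydroxy group in compound 2 is therefore not needed to keep the number at this level, since compound 3 has no hydrogen-bond donor at this place, and the comparison with the compound that lacks the oxygen group altogether tells the same story, with a 1.5-fold lower number from compound 1 to compound 3 (0.18 log units; within the scatter). Nothing measured here explains this result.

All three compounds stay within the scatter of one another, so the compounds shown reveal no change at this place that clearly moves the number in either direction. From the compounds shown here alone, it remains open whether an amine, a carboxylic acid or a longer chain at this place would move the number beyond the scatter, or whether a carbonate with a longer chain than ethyl would stay level with compound 3.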